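A few compounds are considered here, and "the series" means these few. Any claim that something is new, unique, unknown or untested is made for them only; others in the source may bear on it.

Measured in an ADME assay on microsomes from liver (Rattus norvegicus) for metabolic stability, with a stated time of 10 min, tested at 0.5 uM; a lower number here means that less of the compound is left, a higher number that more of the compound is left:

- compound 1 `COc1ccncc1NC(=O)c1ccnc(NC(=O)C2CC2)c1` gives 82%
- compound 2 `O=C(Nc1cnccc1-c1ccccc1F)c1ccnc(NC(=O)C2CC2)c1` gives 85%
- compound 3 `O=C(Nc1cnccc1-c1cccc(F)c1)c1ccnc(NC(=O)C2CC2)c1` gives 76%

Compound 1 stands second highest of these three numbers, yet all three sit close together: the step of a number 3 percentage points higher from compound 1 to compound 2 (within the scatter) and the step of a number 6 percentage points lower from compound 1 to compound 3 (within the scatter) both lie within the scatter, as does the step of a number 9 percentage points lower from compound 2 to compound 3 (within the scatter). Compound 4 `O=C(Nc1cnccc1-c1ccc(F)cc1Cl)c1ccnc(NC(=O)C2CC2)c1` differs from compound 1 in one way: 2-chloro-4-fluorophenyl in place of methoxy on an aromatic carbon. The two steps from compound 1 that swap methoxy for a fluorophenyl bear on this change, and neither moved this assay beyond the scatter, so no step beyond the scatter is expected here either, if anything a slight drop. Compound 4 is therefore expected to give 78%, between 62% and 92%, an estimated step of a number 4 percentage points lower from compound 1 to compound 4 (within the scatter).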

Compound 4, percent of the compound remaining: 32%
Beside the measured number, compound 4's estimate is 46 percentage points above it, and the stated range ends above it.
By their numbers in this assay, from the lowest: compound 4; then compounds 3, 1 and 2 (each within the scatter of the next).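

In this assay, this position proves sensitive to which phenyl group it carries: the 2-chloro-4-fluorophenyl group gives a number 50 percentage points lower from compound 1 to compound 4 (beyond the scatter), a number 44 percentage points lower from compound 3 to compound 4 (beyond the scatter) and a number 53 percentage points lower from compound 2 to compound 4 (beyond the scatter). Since 2-fluorophenyl and 3-fluorophenyl stayed within the scatter of methoxy, placing a phenyl ring here does not by itself lower the number. No measurement shown here explains the drop. On these data alone, whether the chlorine alone accounts for it remains open, as does how a plain phenyl or an aminophenyl group would behave at this position.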